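A few compounds are considered here, and "the series" means these few. Any claim that something is new, unique, unknown or untested is made for them only; others in the source may bear on it.

In a functional assay on IGROV-1 cells (Homo sapiens) for inhibition, read by sulforhodamine B assay, with a stated time of 48 h (on this read-out higher numbers stand for lower toxicity in this test and lower numbers for higher toxicity in this test), compound 1 `COc1ccc(-c2cc(/C=C/C(=O)c3ccc(OC)c(OC)c3)[nH]n2)cc1` gives 8490 nM, and compound 3 `COc1ccc(-c2cc(/C=C/C(=O)c3ccc(N)cc3)[nH]n2)cc1` gives 43300 nM. Compound 2 `COc1cc(-c2cc(/C=C/C(=O)c3ccc(Cl)c(Cl)c3)[nH]n2)cc(OC)c1OC` yields no number in this assay but only its limit, > 100000 nM, so where compound 2 stands on the numbers shown is known only as a limit. That limit is the limit of > 100000 nM in this assay, at which 1 of the 3 values shown sits. Compound 4 `COc1ccc(C(=O)/C=C/c2cc(-c3cc(OC)c(OC)c(OC)c3)n[nH]2)cc1OC` has not yet been measured in this assay. It differs from compound 2 in a single place: 3,4-dimethoxyphenyl in place of 3,4-dichlorophenyl on a carbonyl carbon. Compound 1 carries the same 3,4-dimethoxyphenyl group on its carbonyl carbon and gives a number in this assay, whereas compound 2 gives only a limit. Within the data shown here, no step between measured compounds is available for this change, so the size expected for it rests on that comparison alone. On that basis compound 4 is expected to give a number rather than a limit, with an estimated value of 15000 nM, between 3000 nM and 80000 nM. The estimated step of an at least 6.6-fold lower number from compound 2 to compound 4 (0.82 log units; beyond the scatter) would run toward higher toxicity, with wide uncertainty.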

Compound 4, concentration lethal to 50% of the cells: 6480 nM
Estimate against measurement, compound 4: 2.3-fold (0.36 log units) above; the range from low to high includes it.
By their numbers in this assay, from the lowest: compounds 4 and 1 (each within the scatter of the next); then compound 3. At a limit, above all of these: compound 2.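

In this assay, among these compounds, 3,4-dimethoxyphenyl in place of 3,4-dichlorophenyl on a carbonyl carbon gives an at least 15-fold lower number from compound 2 to compound 4 (1.18 log units; beyond the scatter), the first step that can be read at this position, and it shows that this single change moves the series from a limit onto a measured number. On these data alone, the full size of the step stays unknown, as compound 2 stands only at a limit: the limit of > 100000 nM in this assay, at which 1 of the 4 values shown sits. Compound 4 also shares the 3,4-dimethoxyphenyl group with compound 1, and the two lie within the scatter of each other.

As far as these compounds go, it remains open whether 3,4-dichlorophenyl would also give only a limit on the core of compound 1. From the compounds shown here alone, the standing of an unsubstituted phenyl or a 3,4-dihydroxyphenyl on this carbonyl carbon also remains open.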